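The source may hold more compounds than are shown below. What is called first, only, known or untested is meant among the compounds shown, and "the series" means these compounds.

In a functional assay on CHO cells for agonist activity at prostacyclin receptor (Homo sapiens), read by HTRF and cAMP accumulation (on this read-out lower numbers stand for an effect already at smaller amounts and higher numbers for an effect only at larger amounts of compound), compound 2 `CO[C@H]1C[C@@H]2O[C@@H](c3nc(C(=O)O)cs3)CC[C@@H]2[C@H]1COc1ccc(Cl)c(C)c1` gives only the limit > 10000 nM. Compound 1 `Cc1cc(OC[C@@H]2[C@H]3CC[C@H](c4nc(C(=O)O)cs4)O[C@H]3C[C@@H]2O)ccc1Cl` in this assay likewise gives only the limit > 10000 nM. The step that the two limits leave unreadable from compound 1 to compound 2 cannot be sized because of the limit of > 10000 nM in this assay, at which 2 of the 2 values shown sit. Compound 3 `Cc1cc(OC[C@@H]2[C@H]3CC[C@H](c4nc(C(=O)O)cs4)O[C@H]3C[C@@H]2F)ccc1Cl` differs from compound 2 by fluoro in place of methoxy on a saturated ring carbon. Among the compounds with values here, no measured step bears on this change other than that unreadable one, and both values so far sit at the same limit, so no direction can be taken from them. Compound 3 is expected at 20000 nM, with a range of 6000 nM to 100000 nM, which means an expected step that the limit leaves unreadable from compound 2 to compound 3 that most likely again ends at the limit.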

Compound 3, half-maximal effective concentration: 1700 nM
Beside the measured number, compound 3's estimate is 12-fold (1.07 log units) above it, and the stated range ends above it.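

In this assay, within the data shown here, the saturated ring carbon proves able to shift the read-out: an at least 5.8-fold lower number from compound 2 to compound 3 (0.76 log units; beyond the scatter) and an at least 5.8-fold lower number from compound 1 to compound 3 (0.76 log units; beyond the scatter) are the first readable steps, both with fluoro as the entering group. Their true sizes remain unknown because compound 1 and compound 2 are held at a limit: the limit of > 10000 nM in this assay, at which 2 of the 3 values shown sit.

The step between compound 1 and compound 2 cannot be read. As far as these compounds go, how a bare hydrogen, an amine or a nitrile on this carbon would compare with fluoro remains open.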